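The source may hold more compounds than are shown below. What is called first, only, known or untested is meant among the compounds shown, and "the series" means these compounds.

The compounds are compared in a functional assay on HEL cells (Homo sapiens); a higher number here means that more compound is tolerated, a lower number that less compound is tolerated. Compound 1 `CCCCCOCCCCCCCCCc1cc2cn([C@H]3C[C@H](O)[C@@H](CO)O3)c(=O)nc2o1` reaches only the limit of the assay there, giving > 200000 nM. Compound 2 `CC(C)CCOCCCCCCCCCc1cc2cn([C@H]3C[C@H](O)[C@@H](CO)O3)c(=O)nc2o1`, which carries isopropyl in place of propyl on a saturated chain carbon, two bonds along the chain from an oxygen on a saturated carbon, likewise reaches only the limit, giving > 200000 nM. The step that the two limits leave unreadable from compound 1 to compound 2 cannot be read because of the limit of > 200000 nM in this assay, at which 2 of the 2 values shown sit. On the numbers shown, compound 2 therefore stands at the limit, with no number of its own. Compound 3 `O=c1nc2oc(CCCCCCCCCOCCCCCl)cc2cn1[C@H]1C[C@H](O)[C@@H](CO)O1` differs from compound 2 by 2-chloroethyl in place of isopropyl on a saturated chain carbon, two bonds along the chain from an oxygen on a saturated carbon. For the measured compounds named here, the only measured step touches this change solely through its place on the chain; since its size is not readable, it gives neither a size nor a direction to expect. With both measured compounds sitting at the limit, compound 3 is expected to do the same, so the step of a number no higher from compound 2 to compound 3 (the limit leaves the size open) is estimated to be nothing beyond the scatter in this assay. The estimate for compound 3 is 200000 nM, with a range from 100000 nM to 400000 nM.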

Compound 3, half-maximal cytotoxic concentration: > 200000 nM
Compound 3: only a limit was reported (the forecaster's own chance of this, stated with the estimate: 85%); the middle value lies on the limit itself.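

In this assay, for the compounds shown here, compound 3 also gives only a limit, so no step among compound 1, compound 2 and compound 3 can be read, because all three values sit at the same limit: the limit of > 200000 nM in this assay, at which 3 of the 3 values shown sit. The compounds shown leave open how much of each is actually tolerated in this assay and whether changing isopentyloxy to 4-chlorobutoxy makes any difference.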